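Swapping a hydroxyphenyl for a pyrrole in a thiosemicarbazone

A few compounds are considered here, and "the series" means these few. Any claim that something is new, unique, unknown or untested is made for them only; others in the source may bear on it.

Compound 1 (`CC1=CC[C@H](C(C)(C)NC(=S)N/N=C/c2ccc(O)cc2)CC1`) is examined in a functional assay on U-251 cells (Homo sapiens) for inhibition, read by sulforhodamine B assay, with a stated time of 48 h; on this read-out lower numbers stand for stronger inhibition of growth and higher numbers for weaker inhibition of growth. In this assay compound 1 returns only the limit > 100000 nM. Compound 2 (`CC1=CC[C@H](C(C)(C)NC(=S)N/N=C/c2ccc(N(C)C)cc2)CC1`) likewise returns only the limit > 100000 nM. Compound 3 (`COc1cc(/C=N/NC(=S)NC(C)(C)[C@H]2CC=C(C)CC2)ccc1O`) gives 32600 nM, so the step of an at least 3.0-fold lower number from compound 1 to compound 3 (0.48 log units; beyond the scatter) is readable, while the step that the two limits leave unreadable from compound 1 to compound 2 is not, since (the limit of > 100000 nM in this assay, at which 2 of the 3 values shown sit). Compound 4 (`CC1=CC[C@H](C(C)(C)NC(=S)N/N=C/c2ccc[nH]2)CC1`) differs from compound 1 by 1H-pyrrol-2-yl in place of 4-hydroxyphenyl on a carbon with a double bond to nitrogen. Among the compounds with values here, no measured step changes the aromatic ring itself, so the expectation rests on the single readable step from compound 1 to compound 3, which suggests a modest gain at best. Compound 4 is therefore expected near 60000 nM, within 15000 nM to 150000 nM, an expected step of an at least 1.6-fold lower number from compound 1 to compound 4 (0.22 log units; that floor lies within the scatter).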

Compound 4, concentration for total growth inhibition: 3900 nM
Compound 4: the middle estimate sits 15-fold (1.19 log units) above what was measured; the whole stated range lies above it.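

Compounds 2 and 3 changed only groups on the aromatic ring, while compound 4 replaces the ring itself, and in this assay this gives an at least 25-fold lower number from compound 1 to compound 4 (1.40 log units; beyond the scatter). At this place, on a carbon with a double bond to nitrogen, the identity of the ring therefore strongly affects growth inhibition, and 1H-pyrrol-2-yl is clearly favoured over 4-hydroxyphenyl. The true step may be larger, as compound 1 gives only a limit: the limit of > 100000 nM in this assay, at which 2 of the 4 values shown sit.

This single change alters both ring size and ring atoms, so their separate contributions remain unresolved. On these data alone, whether a furan, thiophene or pyridine ring would perform like the pyrrole also stays open.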